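The compounds below may be only part of what the source reports. "The series", "measured", "known", "first", "only" and "open" are said of these compounds alone.

Three compounds that share one core were tested in an ADME assay on HELF cells (Homo sapiens) for cytotoxicity, with a stated time of 3 days; on this read-out higher numbers stand for lower toxicity in this test and lower numbers for higher toxicity in this test. Compound 1, `CC(C)C[C@H](NC(=O)[C@]1(Cc2ccccc2)CCN1C(=O)OCc1ccccc1)C(N)=O`, gives 50000 nM in this assay. Compound 2, `NC(=O)[C@H](CCC(=O)O)NC(=O)C1(Cc2ccccc2)CCN1C(=O)OCc1ccccc1`, reaches only a limit of the assay there, > 100000 nM, and no number. Compound 3, `C[C@H](NC(=O)[C@@]1(Cc2ccccc2)CCN1C(=O)OCc1ccccc1)C(=O)N(C)C`, likewise stops at a limit of the assay in this assay, > 100000 nM. Compound 3 therefore cannot be placed exactly among the three: it sits at the limit of > 100000 nM in this assay, at which 2 of the 3 values shown sit, and only compound 1 has a numerical value at all. Compound 4, `C[C@H](NC(=O)[C@@]1(Cc2ccccc2)CCN1C(=O)OCc1ccccc1)C(=O)NC1CCCCC1`, is the next compound to be tested and differs from compound 3 in a single place: cyclohexylamino in place of dimethylamino on a carbonyl carbon. Going by the values given here, no pair of measured compounds shows this change, so there is no measured step to lean on. Resting on compound 1, whose value of 50000 nM shows that a different side chain on the same core stays far from strong toxicity, the expected step is an at least 1.2-fold lower number from compound 3 to compound 4 (0.09 log units; that floor lies within the scatter), which is not beyond the usual scatter. Compound 4 is thus estimated at 80000 nM in this assay, within a range from 25000 nM to 250000 nM, with a fair chance that the assay again reports only a limit.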

Compound 4, half-maximal cytotoxic concentration: 46000 nM
Beside the measured number, compound 4's estimate is 1.7-fold (0.24 log units) above it; low and high end bracket the measured number.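

In this assay, going by these compounds alone, putting cyclohexylamino in place of dimethylamino on a carbonyl carbon gives the only step that can be read on this shared core: an at least 2.1-fold lower number from compound 3 to compound 4 (0.33 log units; beyond the scatter). The earlier compounds shown here formed no pair differing in one place, so they could not show that this position responds to a change; here the group with the six-membered ring moves the read-out towards higher toxicity in this test, beyond the usual scatter. This step is only a floor and its full size stays unknown, because compound 3 has a limit of the assay and not a number: the limit of > 100000 nM in this assay, at which 2 of the 4 values shown sit.

The single change brings in a ring, an amide hydrogen and more carbon atoms all at once, and the compounds shown cannot tell which of these matters. Piperidin-1-yl on the same carbonyl carbon would keep a six-membered ring without the amide hydrogen, and an open chain such as hexylamino would keep the amide hydrogen without the ring, so either could begin to separate the two.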